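Salicylanilide series: chloro in place of trifluoromethyl

The compounds below may be only part of what the source reports. "The series", "measured", "known", "first", "only" and "open" are said of these compounds alone.

Going by the values given here, compound 3 `N#Cc1ccc(NC(=O)c2ccc(C(F)(F)F)cc2O)cc1` gives 1030 nM in a functional assay on HL-60 cells (Homo sapiens) for cytotoxicity, read by luminescence and CellTiter-Glo, with a stated time of 3 days (on this read-out higher numbers stand for weaker inhibition and lower numbers for stronger inhibition), the lowest of the three numbers measured so far. Compound 1 `N#Cc1ccc(NC(=O)c2ccc(F)cc2O)cc1` gives 1380 nM and compound 2 `N#Cc1ccc(NC(=O)c2ccc(-c3cccnc3)cc2O)cc1` gives 6660 nM in this assay. Of the measured steps, a 1.3-fold lower number from compound 1 to compound 3 (0.13 log units; within the scatter) lies within the scatter, whereas a 4.8-fold higher number from compound 1 to compound 2 (0.68 log units; beyond the scatter) and a 6.5-fold lower number from compound 2 to compound 3 (0.81 log units; beyond the scatter) lie beyond it, so only the pyridin-3-yl compound 2 stands apart, and compound 3 and compound 1 cannot be ordered against each other.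

Compound 4 `N#Cc1ccc(NC(=O)c2ccc(Cl)cc2O)cc1` is the next member: chloro in place of trifluoromethyl on an aromatic carbon. Chloro enters on the aromatic carbon from which trifluoromethyl leaves, meta to the hydroxy group and para to the large group. The step that bears on this is the exchange between compound 1 and compound 3, where a 1.3-fold lower number from compound 1 to compound 3 (0.13 log units; within the scatter) stayed within the scatter; the step to compound 2 concerns pyridin-3-yl and is less relevant here. In this assay compound 4 is therefore expected to show a 1.2-fold higher number from compound 3 to compound 4 (0.07 log units; within the scatter), that is, no step beyond the scatter. The estimate for compound 4 is 1200 nM, with a range from 500 nM to 3000 nM.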

Compound 4, half-maximal inhibitory concentration: 1300 nM
The estimate for compound 4 lay 1.1-fold (0.03 log units) below the measured number; the range from low to high includes it.
By their numbers in this assay, from the lowest: compounds 3, 4 and 1 (each within the scatter of the next); then compound 2.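

In this assay the position now holds chloro as well as fluoro and trifluoromethyl without any step leaving the scatter (a 1.3-fold higher number from compound 3 to compound 4 (0.10 log units; within the scatter)) (a 1.1-fold lower number from compound 1 to compound 4 (0.03 log units; within the scatter)), so these three groups cannot be told apart here. Pyridin-3-yl now stands apart from all three of these groups, with chloro adding a further step beyond the scatter (a 5.1-fold lower number from compound 2 to compound 4 (0.71 log units; beyond the scatter)), though compound 2 remains the only compound with a ring at this carbon. No measurement shown here accounts for either the lack of separation among compounds 1, 3 and 4 or the separation of compound 2.

On these data alone, whether the step seen with compound 2 follows from a ring as such or from the ring nitrogen stays open, and a phenyl group would address that. Also open, as far as these compounds go, is whether an amine or a carboxylic acid on this carbon would stay with compounds 1, 3 and 4 or move towards compound 2.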